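A new acid linker on a diarylalkyne agonist core

A few compounds are considered here, and "the series" means these few. Any claim that something is new, unique, unknown or untested is made for them only; others in the source may bear on it.

Of the compounds shown here, three built on the same alkyne-linked core have been tested in an in vitro functional assay on 1321-N1 cells for agonist activity at Free fatty acid receptor 1 (Homo sapiens), read by fluorescence; on this read-out higher numbers stand for an effect only at larger amounts of compound and lower numbers for an effect already at smaller amounts. Compound 1 `O=Cc1cccc(C#Cc2ccc(CCC(=O)O)cc2)c1` gives 355 nM, compound 2 `Cc1cccc(C#Cc2ccc(CCC(=O)O)cc2)c1` gives 43.7 nM, and compound 3 `O=C(O)CCc1ccc(C#Cc2cccc(C(F)(F)F)c2)cc1` gives 89.1 nM. Compound 2 therefore stands lowest of the three numbers: there is an 8.1-fold lower number from compound 1 to compound 2 (0.91 log units; beyond the scatter), and there is a 2.0-fold higher number from compound 2 to compound 3 (0.31 log units; beyond the scatter). Going by the values given here, both of these measured changes concern only the single group on the aromatic ring at the far end of the alkyne; the acid-bearing chain is the same in all three compounds.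

Compound 4 `Cc1cccc(C#Cc2ccc(OCC(=O)O)cc2)c1` alters that chain instead: carboxymethoxy in place of 2-carboxyethyl on an aromatic carbon. Among the compounds with values here, none of the measured steps touches this part of the molecule, so the three compounds offer no direct precedent for how this assay responds to it; what they do show is that single-group changes on this core have so far produced only modest shifts. The expectation is therefore a modest rise in the number rather than a large one, and compound 4 is estimated at 110 nM with a range from 30 nM to 400 nM. That estimate corresponds to an expected 2.5-fold higher number from compound 2 to compound 4 (0.40 log units; beyond the scatter), a step that may or may not exceed the scatter.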

Compound 4, half-maximal effective concentration: 513 nM
Compound 4: middle estimate off by 4.7-fold (0.67 log units), on the low side; measured number outside the range, above it.
By their numbers in this assay, from the lowest: compound 2; then compound 3; then compounds 1 and 4 (each within the scatter of the next).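

In this assay, going by these compounds alone, carboxymethoxy in place of 2-carboxyethyl gives a 12-fold higher number from compound 2 to compound 4 (1.07 log units; beyond the scatter), the only step on the shared core rated as large, whereas the exchanges among formyl, methyl and trifluoromethyl were all modest. So this single pair shows that the acid-bearing chain, on an aromatic carbon para to a group of 9 heavy atoms, is a place where the assay number can move strongly, even though the entering and leaving groups both have 5 heavy atoms and differ in the count by one carbon exchanged for one oxygen. Nothing available here accounts for the size of this step.

The compounds shown leave open whether the same chain exchange would have a similar effect with trifluoromethyl or formyl in place of the methyl of compound 2, since it is seen here only with that methyl group. They also leave open how the number would respond to other links between the aromatic ring and the carboxylic acid, such as a thioether sulfur or an amine nitrogen in place of the chain oxygen, or a longer chain.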